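Cyclopropyl to 4-fluorophenyl on an aromatic nitrogen

This account rests on a few compounds, and the source may have more. Where it says the series, first, only, none or still open, it means among the compounds named here.

Measured in an ADME assay on Vero cells (Chlorocebus sabaeus) for cytotoxicity, read by MTT assay, with a stated time of 72 h; a lower number here means a stronger inhibitor, a higher number a weaker inhibitor:
- compound 1 `O=C(O)c1cn(C2CC2)c2nc(N3CCC(n4c(=O)[nH]c5cc(Cl)ccc54)CC3)c([N+](=O)[O-])cc2c1=O` gives 55500 nM
- compound 2 `CCN(CC)C(=O)C1CCCN(c2nc3c(cc2[N+](=O)[O-])c(=O)c(C(=O)O)cn3C2CC2)C1` gives > 136000 nM (a limit)
- compound 3 `O=C(O)c1cn(-c2ccc(F)cc2)c2nc(N3CCN(C(=O)C4COc5ccccc5O4)CC3)c([N+](=O)[O-])cc2c1=O` gives > 54300 nM (a limit)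

Compound 2 stands at the top of the three figures shown, with > 136000 nM, which is a limit and not a number. Compound 4 `CCN(CC)C(=O)C1CCCN(c2nc3c(cc2[N+](=O)[O-])c(=O)c(C(=O)O)cn3-c2ccc(F)cc2)C1` has not yet been measured. It carries 4-fluorophenyl in place of cyclopropyl on an aromatic nitrogen of the shared core (4-fluorophenyl in place of cyclopropyl on an aromatic nitrogen).

Going by the values given here, no measured pair isolates this change, so any expectation for this assay rests on indirect ground. Compound 3 carries the same 4-fluorophenyl and gives > 54300 nM, again a limit. Compound 1 keeps cyclopropyl and gives 55500 nM, so the three compounds show no clean trend with this group. A modest move toward a lower number is therefore expected, and a result no different from compound 2 beyond the usual scatter would not be surprising. The estimated change is an at least 1.6-fold lower number from compound 2 to compound 4 (0.20 log units; that floor lies within the scatter), a small step at most. A reading reported only as a limit is also likely. For compound 4 the expected value is 85000 nM, with an estimated range from 35000 nM to 140000 nM.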

Compound 4, half-maximal inhibitory concentration: > 122000 nM
Compound 4: only a limit was reported; the forecaster's own chance of this, stated with the estimate: 60%; middle value at least 1.4-fold (0.15 log units) away from the limit.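

In this assay compound 2 gives > 136000 nM, a limit. Compound 4 gives > 122000 nM, also a limit. With both values reported as limits, no step can be read between compound 2 and compound 4. The compounds shown leave open whether 4-fluorophenyl in place of cyclopropyl on an aromatic nitrogen changes the read-out in this assay at all.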